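Two ring swaps, one pairing still untested

This account rests on a few compounds, and the source may have more. Where it says the series, first, only, none or still open, it means among the compounds named here.

Compound 1 `Cc1ccc(Nc2nccc(Nc3ccc4nc[nH]c4c3)n2)cc1`, compound 2 `CN1CCN(c2ccc(Nc3nccc(Nc4ccc5nc[nH]c5c4)n3)cc2)CC1` and compound 3 `CN1CCN(c2ccc(Nc3nccc(Nc4ccc5cn[nH]c5c4)n3)cc2)CC1` were examined in an ADME assay on HepG2 cells (Homo sapiens) for inhibition, read by fluorescence and resazurin assay, with a stated time of 72 h; a lower number here means a stronger inhibitor, a higher number a weaker inhibitor. Compound 1 reaches only the assay limit, > 25000 nM. Compound 2 likewise gives only a limit, > 25000 nM. Compound 3 gives 7000 nM. The change 1H-indazol-6-yl in place of 1H-benzimidazol-6-yl on a nitrogen on an aromatic ring produces an at least 3.5-fold lower number from compound 2 to compound 3 (0.55 log units; beyond the scatter). The change methyl in place of 4-methylpiperazin-1-yl on an aromatic carbon produces a step that the two limits leave unreadable from compound 2 to compound 1 because of the limit of > 25000 nM in this assay, at which 2 of the 3 values shown sit. Compound 4 `Cc1ccc(Nc2nccc(Nc3ccc4cn[nH]c4c3)n2)cc1` has not yet been measured; it differs from compound 3 by methyl in place of 4-methylpiperazin-1-yl on an aromatic carbon, the same change as that from compound 2 to compound 1, made at the same place. The size of that step is unreadable from the measured pair, so the expectation for compound 4 rests on compound 3 and its value 7000 nM, with a wide spread. Compound 4 is expected to give 12000 nM, between 4000 nM and 30000 nM. That estimate means a step of a 1.7-fold higher number from compound 3 to compound 4 (0.23 log units; within the scatter).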

Compound 4, half-maximal inhibitory concentration: 18000 nM
Compound 4: the middle estimate sits 1.5-fold (0.18 log units) below what was measured; the range from low to high includes it.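

In this assay, methyl in place of 4-methylpiperazin-1-yl gives a 2.6-fold higher number from compound 3 to compound 4 (0.41 log units; beyond the scatter), so on the core of compound 3 this change leaves a weaker inhibitor, by a step beyond the scatter. Within the data shown here, this is the only readable instance of the change, and it shows its direction and size on that one core. Whether the step carries over to the core of compound 2 cannot be said, because the pair from compound 2 to compound 1 cannot be read: the limit of > 25000 nM in this assay, at which 2 of the 4 values shown sit.

The compounds shown leave open how other groups at this place, such as a morpholine, a carboxylic acid or a longer amine chain, would read in this assay.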